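The source may hold more compounds than are shown below. What is called first, only, known or untested is meant among the compounds shown, and "the series" means these compounds.

Working notes on the series. The read-out is a functional assay on DLD-1 cells (Homo sapiens) for antiproliferative activity, read by CellTiter-Glo, with a stated time of 72 h (on this read-out higher numbers stand for weaker inhibition and lower numbers for stronger inhibition), and three compounds have numbers on it. Compound 1 `Cc1cc(C)c(S(=O)(=O)N2CCC(N3CCC(c4ccccc4)CC3)CC2)c(C)c1` gives 865 nM in this assay. Compound 2 `Cc1cc(C)c(S(=O)(=O)NCCN2CCC(C)CC2)c(C)c1` gives 1900 nM, a higher number than compound 1, beyond the scatter. Compound 3 `CC1CCN(C2CCN(S(=O)(=O)c3cccc(-c4ccc(F)cc4)c3)CC2)CC1` gives 12 nM, a lower number than compound 1, beyond the scatter. Compound 1 thus stands second highest of the three numbers, nearest to compound 2 and furthest from compound 3.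

The step under consideration leads to compound 4 `C#CCCC(=O)CC1CCN(C2CCN(S(=O)(=O)c3c(C)cc(C)cc3C)CC2)CC1`. Relative to compound 1 the change is ((but-3-yn-1-yl)carbonyl)methyl in place of phenyl on a saturated ring carbon. For the measured compounds named here, no measured pair in the set isolates this change, and compound 3 differs from compound 1 in more than this one place, so its number cannot be read as a guide to the step. The expectation for the step from compound 1 to compound 4 in this assay is therefore a small one, a 1.2-fold lower number from compound 1 to compound 4 (0.09 log units; within the scatter), with no direction that can be claimed beyond the scatter. Compound 4 is estimated at 700 nM in this assay, within a range of 150 nM to 3000 nM.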

Compound 4, half-maximal inhibitory concentration: 3 nM
Compound 4: the middle estimate sits 230-fold (2.37 log units) above what was measured; measured number outside the range, below it.
By their numbers in this assay, from the lowest: compound 4; then compound 3; then compound 1; then compound 2.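

In this assay this position, on a saturated ring carbon three ring bonds from the ring nitrogen, responds strongly to what it carries: ((but-3-yn-1-yl)carbonyl)methyl in place of phenyl gives a 290-fold lower number from compound 1 to compound 4 (2.46 log units; beyond the scatter). An aromatic ring at this place is therefore not needed for a low number, as the entering group has no ring and brings a carbonyl, a triple bond and one hydrogen-bond acceptor, where phenyl has none of these. No measurement in hand bears on the reason for the size of this step.

For the compounds shown here, the single step changes all these features at once, so it remains open whether the carbonyl, the triple bond, the chain itself or the loss of phenyl accounts for the lower number. A saturated pentyl-type ketone without the triple bond, the matching alcohol in place of the carbonyl, an open chain with no carbonyl, or a longer chain at this place would each separate these parts, and a benzyl group would show whether an aromatic ring is tolerated once set further out.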